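Working notes: exchanging the methylsulfonyl group of compound 3

A few compounds are considered here, and "the series" means these few. Any claim that something is new, unique, unknown or untested is made for them only; others in the source may bear on it.

Measured compounds:
compound 1, `Cc1nc2c(OCc3ccccc3)cccn2c1C(N)=O`: in a functional assay on the whole organism with Rattus norvegicus as the target, with a stated time of 4 h, at a dose of 40 mg/kg by the intraperitoneal route (a higher number here means more inhibition at the dose given (going by the name of the read-out), a lower number less inhibition), compound 1 gives 42%
compound 2, `Cc1nc2c(OCc3ccccc3)cccn2c1C#N`: in this assay compound 2 gives 25%
compound 3, `Cc1nc2c(OCc3ccccc3)cccn2c1CS(C)(=O)=O`: in this assay compound 3 gives 61%

Compound 3 stands highest of the three. Its nearest neighbour is compound 1, with a number 19 percentage points higher from compound 1 to compound 3 (beyond the scatter); its furthest is compound 2, with a number 36 percentage points higher from compound 2 to compound 3 (beyond the scatter). Between the two lower compounds the step is a number 17 percentage points lower from compound 1 to compound 2 (beyond the scatter).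

Compound 4, `Cc1nc2c(OCc3ccccc3)cccn2c1COC(=O)N(C)C`, is not yet measured. It differs from compound 3 in one place: (dimethylcarbamoyl)oxy in place of methylsulfonyl on a saturated chain carbon bound to an aromatic carbon. Among the compounds with values here, none of the measured steps exchanges one group for another on this saturated chain carbon; all three change the group on the aromatic carbon itself. They show only that this assay answers to changes at this position with modest to large steps, and that the (methylsulfonyl)methyl group of compound 3 gave the highest number. With the methylsulfonyl part removed, a step downward beyond the scatter is expected, of modest size. Compound 4 is expected to give 45%, within 25% to 65%. The expected step is a number 16 percentage points lower from compound 3 to compound 4 (beyond the scatter).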

Compound 4, a percentage reported as inhibition, in the whole organism at one dose (the size of the read-out at that dose, not a potency): 75%
The estimate for compound 4 lay 30 percentage points below the measured number, outside the stated range (above it).
By their numbers in this assay, from the lowest: compound 2; then compound 1; then compound 3; then compound 4.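

The saturated chain carbon bound to an aromatic carbon does not need the methylsulfonyl group for a high number: in this assay, (dimethylcarbamoyl)oxy in its place gives a number 14 percentage points higher from compound 3 to compound 4 (beyond the scatter) on exchange. Against the groups on the aromatic carbon itself, ((dimethylcarbamoyl)oxy)methyl gives both a number 50 percentage points higher from compound 2 to compound 4 (beyond the scatter) and a number 33 percentage points higher from compound 1 to compound 4 (beyond the scatter) as large steps, which places compound 4 highest of the four, with every step to it beyond the scatter. Nothing measured here bears on what lies behind this gain.

On these data alone, it remains open whether the number follows the whole (dimethylcarbamoyl)oxy group or only part of it, which a hydroxyl, an acetoxy or a dimethylamino group on the same saturated chain carbon would help to separate. Also open, as far as these compounds go, is whether the order of the four holds at other doses and times.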